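A few compounds are considered here, and "the series" means these few. Any claim that something is new, unique, unknown or untested is made for them only; others in the source may bear on it.

Compound 1 `COc1cc(CNC(=O)CCCC/C=C/C(C)C)ccc1OCCCCOc1ccc(C(N)=S)cc1` and compound 2 `COc1cc(CNC(=O)CCCC/C=C/C(C)C)ccc1OCCCCCOc1ccc(C(N)=S)cc1` share a long chain that links two aromatic rings; the two cores differ by a group of 11 heavy atoms (8 carbon, 1 nitrogen, 1 oxygen, 1 sulfur; one six-membered aromatic ring of carbon only) in place of a group of 10 heavy atoms (7 carbon, 1 nitrogen, 1 oxygen, 1 sulfur; one six-membered aromatic ring of carbon only), on a saturated chain carbon, four bonds along the chain from an oxygen on an aromatic ring. In a functional assay on K562 cells (Homo sapiens) for antiproliferative activity, read by MTT assay, with a stated time of 48 h (on this read-out higher numbers stand for weaker inhibition and lower numbers for stronger inhibition), compound 1 gives only a limit of the assay, > 50000 nM. In this assay compound 2 likewise gives only a limit, > 50000 nM. The step that the two limits leave unreadable from compound 1 to compound 2 therefore cannot be sized.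

Compound 3 `COc1cc(CNC(=O)CCCC/C=C/C(C)C)ccc1OCCCCOc1ccc(-c2cc(=S)ss2)cc1` carries the core of compound 1 with a further change, (a group of 6 heavy atoms (3 carbon, 3 sulfur; one five-membered aromatic ring with 2 hetero atoms) in place of a group of 3 heavy atoms (1 carbon, 1 nitrogen, 1 sulfur; no ring), on an aromatic carbon). In this assay compound 3 again gives only a limit, > 50000 nM. The step that the two limits leave unreadable from compound 1 to compound 3 is equally unreadable, because all three values sit at the limit of > 50000 nM in this assay, at which 3 of the 3 values shown sit.

Compound 4 `COc1cc(CNC(=O)CCCC/C=C/C(C)C)ccc1OCCCCCOc1ccc(-c2cc(=S)ss2)cc1` stands to compound 2 as compound 3 stands to compound 1: the change is a group of 6 heavy atoms (3 carbon, 3 sulfur; one five-membered aromatic ring with 2 hetero atoms) in place of a group of 3 heavy atoms (1 carbon, 1 nitrogen, 1 sulfur; no ring), on an aromatic carbon, the same kind of change at the same place, on an aromatic carbon of a six-membered aromatic ring of carbon only, para to a large group. Nothing measured here points to a gain in potency from either kind of change, so the step from compound 2 to compound 4 is expected to be about a step that the limit leaves unreadable from compound 2 to compound 4, resting on the three values that all stop at the limit. For compound 4 the value in this assay is expected near 80000 nM, within roughly 30000 nM to 250000 nM, and most likely reported as a limit rather than a number.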

Compound 4, half-maximal inhibitory concentration: > 50000 nM
Compound 4: no number, only a limit; the forecaster's own chance of this, stated with the estimate: 85%; the middle value is on the limit's open side.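

In this assay compound 4 gives only a limit, > 50000 nM. Compound 2 also stops at a limit, so no step can be read between compound 2 and compound 4, and the comparison stays without a size: the limit of > 50000 nM in this assay, at which 4 of the 4 values shown sit.

The compounds shown leave open how potent any of the four really is, and whether either kind of structural change shifts potency at all.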